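Chain variation at the amino-acid side chain: compound 4

This account rests on a few compounds, and the source may have more. Where it says the series, first, only, none or still open, it means among the compounds named here.

Three compounds share one core and differ only in the side chain of the amino-acid part. In a functional assay on the whole organism (Tail, strain ICR) with Mus musculus as the target, in the tail flick test, with a stated time of 60 min, at a dose of 25 umol/kg by the oral route (on this read-out higher numbers stand for a stronger effect at the one dose given and lower numbers for a weaker effect), compound 1 `O=C(O)CC[C@H](NC(=O)CN(c1nc(Cl)nc2[nH]cnc12)C1CC1)C(=O)O` gives 33.3%, compound 2 `NC(=O)CC[C@H](NC(=O)CN(c1nc(Cl)nc2[nH]cnc12)C1CC1)C(=O)O` gives 38.4%, and compound 3 `CSCC[C@H](NC(=O)CN(c1nc(Cl)nc2[nH]cnc12)C1CC1)C(=O)O` gives 22.8%. Compound 3 stands lowest of the three; the step of a number 10.5 percentage points lower from compound 1 to compound 3 (beyond the scatter) and the step of a number 15.6 percentage points lower from compound 2 to compound 3 (beyond the scatter) both go down, while the step of a number 5.1 percentage points higher from compound 1 to compound 2 (within the scatter) stays within the scatter.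

Compound 4 `CC(C)C[C@H](NC(=O)CN(c1nc(Cl)nc2[nH]cnc12)C1CC1)C(=O)O` is not yet measured. The change from compound 3 is isopropyl in place of (methylsulfanyl)methyl on a saturated chain carbon, two bonds along the chain from an amide-type nitrogen and a carbonyl carbon. Among the measured compounds shown here, no measured step concerns an isopropyl; the two steps that bear on it are the ones into compound 3, in which a group with a hydrogen-bond acceptor or donor gave way to the methylsulfanyl group and the number fell modestly. The change to compound 4 removes the last acceptor from the side chain, so a further small fall or no step beyond the scatter is expected in this assay, the estimated step being a number 5.8 percentage points lower from compound 3 to compound 4 (within the scatter). Compound 4 is therefore estimated at 17%, within 7% to 30%.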

Compound 4, a percentage reported as activity, at one dose (the size of the read-out at that dose, not a potency): 36.4%
The estimate for compound 4 lay 19.4 percentage points below the measured number; measured number outside the range, above it.
By their numbers in this assay, from the lowest: compound 3; then compounds 1, 4 and 2 (each within the scatter of the next).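

Working from this assay, the isopropyl chain has no hydrogen-bond donor or acceptor, and still a number 13.6 percentage points higher from compound 3 to compound 4 (beyond the scatter) is seen, so a donor or acceptor on this side chain is not required for the read-out. Neither a number 2 percentage points lower from compound 2 to compound 4 (within the scatter) nor a number 3.1 percentage points higher from compound 1 to compound 4 (within the scatter) separates isopropyl from carbamoylmethyl or carboxymethyl, and compound 3, with (methylsulfanyl)methyl, is the only one of the four printed as beyond the scatter from all the others. No measurement shown accounts for the separate position of compound 3.

As far as these compounds go, whether an aminobutyl chain, a benzyl group or a simple methyl at this position would stay with compound 1, compound 2 and compound 4 or fall with compound 3 remains open. A read-out at a single dose also leaves open how these compounds compare in potency.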